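Amino Enters the Aromatic Core of Compound 1

The source may report more compounds than this note shows. Statements on the series, on what has been measured and on what is new or still open speak of the compounds shown alone.

Compound 1 `O=C(COc1cccc2ccccc12)N1CCCC1` is the starting point. In a functional assay on the whole organism with Mus musculus as the target, in the elevated plus maze, with a stated time of 24 h, at a dose of 3 mg/kg by the intraperitoneal route (a higher number here means a stronger effect of the compound at the dose given, a lower number a weaker effect), compound 1 gives 68.4%, the lowest of the three numbers. Compound 2 `O=C(COc1cccc2ccccc12)N1CCOCC1` gives 81.7% and compound 3 `CN(C)C(=O)COc1cccc2ccccc12` gives 77.8%; the steps are a number 13.3 percentage points higher from compound 1 to compound 2 (beyond the scatter) and a number 9.4 percentage points higher from compound 1 to compound 3 (within the scatter). Compound 4 `Nc1cccc2c(OCC(=O)N3CCCC3)cccc12` differs from compound 1 by amino in place of hydrogen on an aromatic carbon. For the measured compounds named here, all three measured steps concern the group on the carbonyl carbon; none of them touches the aromatic core, so no measured step bears on this change. The expectation for compound 4 is therefore a step of a number 0.4 percentage points lower from compound 1 to compound 4 (within the scatter) in this assay, not beyond the scatter. Compound 4 is estimated to give 68%, within a range of 50% to 86%.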

Compound 4, a percentage reported as activity, at one dose (the size of the read-out at that dose, not a potency): 74.5%
Compound 4: the middle estimate sits 6.5 percentage points below what was measured, and the stated range covers the measured number.
By their numbers in this assay, from the lowest: compounds 1, 4, 3 and 2 (each within the scatter of the next, the first and the last beyond it).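

In this assay, amino in place of hydrogen on an aromatic carbon is the only change to the shared core among the compounds shown, and it gives a number 6.1 percentage points higher from compound 1 to compound 4 (within the scatter) as its step. This position, ortho to a fused ring and meta to a fused ring, therefore accepts amino with no change beyond the scatter. Nothing available explains this step. As far as these compounds go, whether a hydroxyl, a methoxy or an acetylamino group at this position would behave alike remains open. Also open, from the compounds shown here alone, is how amino here would read with morpholin-4-yl or dimethylamino on the carbonyl carbon.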